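The compounds below may be only part of what the source reports. "The series", "measured", "known", "first", "only" and "open" are said of these compounds alone.

Compound 2 `COc1cccc(CNCCCNc2ccnc3cc(Oc4cccc(N(C)C)c4)ccc23)c1O` and compound 1 `CN(C)c1cccc(Oc2ccc3c(NCCCNCc4ccco4)ccnc3c2)c1` share one core. In an ADME assay for permeability, using PAMPA, with a stated time of 30 min, at pH 7.4 (on this read-out higher numbers stand for higher permeability and lower numbers for lower permeability), compound 1 gives 317 10^-6 cm/s, and in this assay compound 2 gives 317 10^-6 cm/s; the step of no change at the digits printed from compound 1 to compound 2 (within the scatter) leaves compound 2 level with compound 1 at the digits shown. Compound 3 `COc1cccc(CNCCCNc2ccnc3cc(Cc4ccc(F)cc4Cl)ccc23)c1O` differs from compound 2 by 2-chloro-4-fluorobenzyl in place of 3-(dimethylamino)phenoxy on an aromatic carbon. Going by the values given here, no measured step touches this position or this kind of exchange; the only measured step, no change at the digits printed from compound 1 to compound 2 (within the scatter), concerns the chain end and was flat. With nothing to set a direction, the expected step of a 1.1-fold lower number from compound 2 to compound 3 (0.02 log units; within the scatter) is none beyond the scatter. For compound 3 the estimate in this assay is 300 10^-6 cm/s, between 150 10^-6 cm/s and 600 10^-6 cm/s.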

Compound 3, apparent permeability: 23 10^-6 cm/s
Estimate against measurement, compound 3: 13-fold (1.12 log units) above; measured number outside the range, below it.
By their numbers in this assay, from the lowest: compound 3; then compounds 1 and 2 (each within the scatter of the next).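

Unlike the chain-end exchange, the exchange at this aromatic carbon moves the read-out in this assay: 2-chloro-4-fluorobenzyl in place of 3-(dimethylamino)phenoxy gives a 14-fold lower number from compound 2 to compound 3 (1.14 log units; beyond the scatter). The position is therefore not silent in the way the chain end was, at least for this pair. Nothing measured bears on the reason for the fall.

The exchange alters the linking atom and the ring substituents together, so a 3-(dimethylamino)benzyl or a 2-chloro-4-fluorophenoxy group would be needed to separate them. On these data alone, whether furan-2-yl at the chain end remains equivalent alongside 2-chloro-4-fluorobenzyl also stays open.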